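The compounds below may be only part of what the source reports. "The series", "measured", "known", "first", "only" and "open" are said of these compounds alone.

Two compounds carrying a shared benzotriazole-type core built from a fused bicyclic system are on record, and a third awaits testing. Compound 1 `Fc1ccccc1-c1ccc(Cn2nnc3ccccc32)cn1` has no result in an ADME assay on microsomes from liver (Rattus norvegicus, strain Wistar) for metabolic stability, tested at 2.5 uM; a higher number here means faster removal of the compound, a lower number slower removal; for compound 1 the outcome is "not determined" (no result reported). Among the measured compounds shown here, compound 2 `Fc1ccc(Cn2nnc3c(Br)cccc32)cc1` is therefore the only compound with a number: in this assay compound 2 gives 1 mL/min/g. For the measured compounds named here, no step between two measured compounds can be drawn from this pair, since compound 1 contributes no number.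

The move to compound 3 `Brc1ccc(Cn2nnc3c(Br)cccc32)cc1` is small in terms of atoms: bromo in place of fluoro on an aromatic carbon. Going by the values given here, nothing among the measured compounds shows how such a swap plays out in this assay, so the expectation leans on the value of compound 2 alone. A step from compound 2 to compound 3 of a 1.5-fold higher number from compound 2 to compound 3 (0.18 log units; within the scatter) is expected, which is an upward move that stays close to the usual scatter rather than clearly beyond it. Among the compounds with values here, for compound 3 the estimated result in this assay is 1.5 mL/min/g, with a range from 0.6 mL/min/g to 4 mL/min/g, resting on the single value of compound 2 at 1 mL/min/g.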

Compound 3, intrinsic clearance in a liver preparation (reported as CLH), per the amount of preparation that the assay uses: 2.2 mL/min/g
Beside the measured number, compound 3's estimate is 1.5-fold (0.17 log units) below it; low and high end bracket the measured number.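

In this assay, bromo in place of fluoro on an aromatic carbon, para to a large group, gives a 2.2-fold higher number from compound 2 to compound 3 (0.34 log units; beyond the scatter), the first step available for this position. Until now the series offered a single number and no comparison, so it could not show whether this position mattered in this assay at all; it now shows that exchanging one heavy atom for another, with no ring, hydrogen-bond donor, hydrogen-bond acceptor or net charge entering or leaving, is enough to carry the read-out modestly beyond the usual scatter, towards faster removal. No supporting data accompany this step, so the reason for the shift remains unknown.

The compounds shown leave open whether a chloro group, a methoxy group or an amine at the same place would give a number close to those of compound 2 and compound 3 or one well away from both. Among the compounds shown here, with only this pair to compare, they also leave open whether the step reflects a wider trend at this position or holds for this pair alone.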